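Replacing chloro with hydrogen on compound 1

This account rests on a few compounds, and the source may have more. Where it says the series, first, only, none or still open, it means among the compounds named here.

Measured so far in a functional assay on SW982 cells (Homo sapiens) for inhibition, read by MTT assay, with a stated time of 72 h; a higher number here means a weaker inhibitor, a lower number a stronger inhibitor:
- compound 1 `COc1cc(OC)c(OC)cc1/C=C/C(=O)c1ccc(Cl)cc1` gives 58500 nM
- compound 2 `COc1cc(OC)c(OC)cc1/C=C/C(=O)c1cc(OC(C)=O)ccc1OC(C)=O` gives 78500 nM
- compound 3 `COc1cc(OC)c(OC)cc1/C=C/C(=O)c1cc(Cc2ccccc2)cc(Cc2ccccc2)c1` gives 69900 nM

The three values lie within the scatter of one another, so compound 1 stands level with compound 2 and compound 3, and no order can be read among them. All three share a core and differ in the substituents it carries. Among the measured compounds shown here, no measured pair differs in one place only, so the series offers no direct measure of a single change.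

The next compound is compound 4 `COc1cc(OC)c(OC)cc1/C=C/C(=O)c1ccccc1` with hydrogen in place of chloro on an aromatic carbon, para to a large group. The difference from compound 1 reads hydrogen in place of chloro on an aromatic carbon and amounts to 4-chlorophenyl to phenyl.

No step beyond the scatter is expected in this assay, since compound 1 at 58500 nM and compound 2 at 78500 nM and compound 3 at 69900 nM stay together although their substituents differ widely. The direction of any shift cannot be told from these data. The estimated change is a 1.0-fold higher number from compound 1 to compound 4 (0.01 log units; within the scatter) and it is expected to stay within the scatter. Compound 4 is expected at about 60000 nM, with an estimated range of 25000 nM to 120000 nM.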

Compound 4, half-maximal inhibitory concentration: > 150000 nM
Compound 4 gave a limit, no number; the forecaster's own chance of this, stated with the estimate: 10%; middle value at least 2.5-fold (0.39 log units) from the limit.
By their numbers in this assay, from the lowest: compounds 1, 3 and 2 (each within the scatter of the next). At a limit, above all of these: compound 4.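

In this assay compound 4 gives > 150000 nM, which is a limit of the assay and not a number. Hydrogen in place of chloro on an aromatic carbon, para to a large group, thus gives an at least 2.5-fold higher number from compound 1 to compound 4 (0.40 log units; beyond the scatter), the first change in one place that can be read in this series, and it shows that this position is not indifferent to what it carries. The chloro of compound 1 counts for the inhibition seen here, while the full size of the step stays unknown, since one end of it is a limit: the limit of > 150000 nM in this assay, at which 1 of the 4 values shown sits.

On these data alone, with only chloro and hydrogen compared at this carbon, it remains open whether the gain belongs to chloro alone or would also come with fluoro, bromo, a methyl group, an amine or a carboxylic acid in the same place. Also open, as far as these compounds go, is whether the same change would matter in the same way on a compound carrying other substituents, such as the two acetoxy groups of compound 2 or the two benzyl groups of compound 3, neither of which has a partner differing in one place.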